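The compounds below may be only part of what the source reports. "The series", "measured", "known", "first", "only" and "open" are said of these compounds alone.

Measured so far:
Compound 1 `O=C(NCc1ccc(S(=O)(=O)N2CCC(O)CC2)cc1)N1Cc2ccncc2C1`: in an assay on isolated protein for inhibition of Nicotinamide phosphoribosyltransferase (Homo sapiens), read by mass spectrometry, with stated times of 15 min and 30 min (on this read-out lower numbers stand for stronger inhibition and higher numbers for weaker inhibition), compound 1 gives 44 nM.
Compound 2 `O=C(NCc1ccc(S(=O)(=O)N2CCC[C@@H](O)C2)cc1)N1Cc2ccncc2C1`: in this assay compound 2 gives 28 nM.

Compound 2 shows the lower of the two numbers, but the gap is only a 1.6-fold lower number from compound 1 to compound 2 (0.20 log units; within the scatter), within the scatter. Compound 3 `O=C(NCc1ccc(S(=O)(=O)N2CCC[C@H](O)C2)cc1)N1Cc2ccncc2C1` is the next step: the two compounds have the same atoms and bonds and differ only in configuration as drawn: 1 of 1 stereo elements differ; a stereocentre at a saturated ring carbon is drawn R in compound 2 and S in compound 3. Among the compounds with values here, no measured step bears on a change of configuration alone; the one step recorded, from compound 1 to compound 2, exchanges one hydroxypiperidinyl group for another and gives no guidance here. The step of a 1.6-fold higher number from compound 2 to compound 3 (0.21 log units; within the scatter) is therefore expected to be small, with no direction beyond the scatter, and with wide uncertainty. Compound 3 is estimated at 45 nM, range 15 nM to 200 nM.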

Compound 3, half-maximal inhibitory concentration: 770 nM
Beside the measured number, compound 3's estimate is 17-fold (1.23 log units) below it; the measured number lies above the stated range.
By their numbers in this assay, from the lowest: compounds 2 and 1 (each within the scatter of the next); then compound 3.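

Configuration at this saturated ring carbon of the 3-hydroxypiperidin-1-yl group carries a large effect, with a 28-fold higher number from compound 2 to compound 3 (1.44 log units; beyond the scatter). That step can be assigned to the stereocentre alone because of what separates the pair: the fact that compounds 2 and 3 differ only in the configuration as drawn. Exchange of 4-hydroxypiperidin-1-yl for 3-hydroxypiperidin-1-yl therefore stays within the scatter only with the R drawing, while the S drawing in compound 3 gives an 18-fold higher number from compound 1 to compound 3 (1.24 log units; beyond the scatter).

Open, on these data alone, is whether a methoxy group or an amine in place of the hydroxyl keeps this preference for the R drawing. Also open, as far as these compounds go, is whether a stereocentre on the 4-substituted piperidine, as with an added methyl group, would matter to the same degree.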